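The source may hold more compounds than are shown below. What is called first, only, known or untested is meant among the compounds shown, and "the series" means these compounds.

Measured in a functional assay on A549 cells (Homo sapiens) for cytotoxicity, read by MTT assay, with a stated time of 24 h, tested at 10 uM; on this read-out lower numbers stand for a stronger effect and higher numbers for a weaker effect at the one concentration tested:

- compound 1 `CCCCCCCCCCCCCOC(=O)CCC(=O)N1CCN(CCCOc2cc3c(Nc4ccc(F)c(Cl)c4)ncnc3cc2OC)CC1`: 93.7%
- compound 2 `CCCCCCCCCCCCCCCOC(=O)CCC(=O)N1CCN(CCCOc2cc3c(Nc4ccc(F)c(Cl)c4)ncnc3cc2OC)CC1`: 92%
- compound 3 `CCCCCCCCCCCCCCCCCCCOC(=O)CCC(=O)N1CCN(CCCOc2cc3c(Nc4ccc(F)c(Cl)c4)ncnc3cc2OC)CC1`: 94.5%

Compound 3 gives the largest of the three numbers in this assay, but the margins are slight: a number 0.8 percentage points higher from compound 1 to compound 3 (within the scatter) and a number 2.5 percentage points higher from compound 2 to compound 3 (within the scatter) both fall within the scatter, as does a number 1.7 percentage points lower from compound 1 to compound 2 (within the scatter). Across the series, then, lengthening the saturated chain at the same place each time has produced no movement beyond the noise of the read-out.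

Compound 4 `CCCCCCCCCCCCCCCCCCCCOC(=O)CCC(=O)N1CCN(CCCOc2cc3c(Nc4ccc(F)c(Cl)c4)ncnc3cc2OC)CC1` continues the same series by a single step, (methyl in place of hydrogen on a saturated chain carbon, ten or more bonds along the chain from an oxygen next to a carbonyl group).

The three measured steps all bear on this change, since each is a chain extension at the same place, and none exceeded the scatter. The same is therefore expected here: no step beyond the scatter in this assay, in either direction, and a number close to that of compound 3.

The expected step is a number 0.5 percentage points lower from compound 3 to compound 4 (within the scatter).

Compound 4 is estimated at 94%, in the range 87% to 100%.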

Compound 4, a percentage reported as activity, at one concentration (the size of the read-out at that concentration, not a potency): 94%
Estimate against measurement, compound 4: no gap at the digits printed, and the stated range covers the measured number.
By their numbers in this assay, from the lowest: compounds 2, 1, 4 and 3 (each within the scatter of the next).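

In this assay, methyl in place of hydrogen on a saturated chain carbon, ten or more bonds along the chain from an oxygen next to a carbonyl group, gives a step within the scatter (a number 0.5 percentage points lower from compound 3 to compound 4 (within the scatter)), so even the smallest extension in the series leaves the read-out unmoved. The larger pentyl and heptyl changes now read the same way (a number 2 percentage points higher from compound 2 to compound 4 (within the scatter); a number 0.3 percentage points higher from compound 1 to compound 4 (within the scatter)), and heptyl is the largest change in the set, so all four compounds sit within the scatter of one another at this position. No supporting data on hand bear on why the read-out stays flat.

All four compounds carry a plain saturated chain at this place, which leaves open whether an amine, a carboxylic acid or a much shorter chain would produce a step beyond the scatter. From the compounds shown here alone, whether the same flat picture holds at a higher concentration or a longer exposure also stays open.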